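Acylsulfonamide series: rat microsomal stability, sulfonyl substituent change

This account rests on a few compounds, and the source may have more. Where it says the series, first, only, none or still open, it means among the compounds named here.

Measured so far:
Compound 1 `CC(C)(C)NC(=O)NCCS(=O)(=O)NC(=O)c1ccc(Nc2nc(NC3(c4ccc(Cl)cc4)CC3)nc(OCC(F)(F)F)n2)cc1`: 93%
Compound 2 `O=C(NS(=O)(=O)CCNC(=O)C1CC1)c1ccc(Nc2nc(NC3(c4ccc(Cl)cc4)CC3)nc(OCC(F)(F)F)n2)cc1`: "not active" (no number reported)
Compound 3 `CNC(=O)NCCS(=O)(=O)NC(=O)c1ccc(Nc2nc(NC3(c4ccc(Cl)cc4)CC3)nc(OCC(F)(F)F)n2)cc1`: 100%

For the measured compounds named here, in an ADME assay on microsomes from liver (Rattus norvegicus) for metabolic stability, with a stated time of 10 min (on this read-out higher numbers stand for a more stable compound and lower numbers for a less stable compound), compound 3 and compound 1 lie within the scatter of each other; the only counted step, a number 7 percentage points higher from compound 1 to compound 3 (within the scatter), is within the scatter. Compound 2 returned no number in this assay.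

Compound 4 `CN(C)S(=O)(=O)NC(=O)c1ccc(Nc2nc(NC3(c4ccc(Cl)cc4)CC3)nc(OCC(F)(F)F)n2)cc1` differs from compound 3 by dimethylamino in place of 2-((methylcarbamoyl)amino)ethyl on a sulfonyl sulfur. Going by the values given here, no measured step alters the sulfonyl substituent itself; the one counted step changed only the urea end and stayed within the scatter. The expectation for compound 4 in this assay is therefore a step of a number 10 percentage points lower from compound 3 to compound 4 (within the scatter), i.e. none beyond the scatter, with the lower end of the range left open for loss of the chain. Compound 4 is estimated at 90%, range 70% to 100%.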

Compound 4, percent of the compound remaining: 76%
Estimate against measurement, compound 4: 14 percentage points above; measured number inside the range.
By their numbers in this assay, from the lowest: compound 4; then compounds 1 and 3 (each within the scatter of the next).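

For the compounds shown here, the sulfonyl sulfur is the first position where a change moves the read-out beyond the scatter: in this assay, dimethylamino in place of 2-((methylcarbamoyl)amino)ethyl gives a number 24 percentage points lower from compound 3 to compound 4 (beyond the scatter), and in place of 2-(((tert-butyl)carbamoyl)amino)ethyl it gives a number 17 percentage points lower from compound 1 to compound 4 (beyond the scatter). The sulfonyl substituent therefore matters here in a way the urea end did not. Nothing available explains the drop.

The change removes the chain and places a nitrogen on the sulfur in a single step, and these two parts remain unseparated. A plain methyl or a 2-aminoethyl group on the sulfonyl sulfur would pull them apart.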